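The source may hold more compounds than are shown below. What is called first, only, known or untested is meant among the compounds shown, and "the series" means these compounds.

- Compound 1 `CCOC(=O)c1ccc(-c2nn(Cc3cccc(F)c3)c3ccccc23)cc1`: 270 nM
- Compound 2 `CCOC(=O)c1ccc(-c2nn(Cc3ccccn3)c3ccccc23)cc1`: 290 nM
- Compound 3 `CCOC(=O)c1ccc(-c2nn(Cc3cccnc3)c3ccccc23)cc1`: not yet measured

In a functional assay on cells (Platelet, Homo sapiens) for inhibition (on this read-out lower numbers stand for stronger inhibition and higher numbers for weaker inhibition), compound 2 gives 290 nM and compound 1 gives 270 nM, so the two cannot be told apart beyond the usual scatter of repeated measurements.

Compound 3 has the same atoms as compound 2, joined differently: pyridin-3-yl in place of pyridin-2-yl on a saturated chain carbon bound to an aromatic nitrogen. Put simply, pyridin-3-yl stands in place of pyridin-2-yl on a saturated chain carbon bound to an aromatic nitrogen.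

Among the measured compounds shown here, only one measured step concerns that place. For the measured compounds named here, it is a 1.1-fold higher number from compound 1 to compound 2 (0.03 log units; within the scatter), seen when pyridin-2-yl replaced 3-fluorophenyl, and it gives the sole guide to what a ring exchange there may do. Going by the values given here, no compound carrying pyridin-3-yl has been measured, so this evidence is indirect. No step beyond the scatter is therefore expected in this assay, in either direction. The estimated step is a 1.0-fold higher number from compound 2 to compound 3 (0.01 log units; within the scatter) and it should be read as no real change. Compound 3 is expected to give 300 nM, with an estimated range from 130 nM to 700 nM.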

Compound 3, half-maximal inhibitory concentration: 5550 nM
Compound 3: the middle estimate sits 19-fold (1.27 log units) below what was measured, and the stated range ends below it.
By their numbers in this assay, from the lowest: compounds 1 and 2 (each within the scatter of the next); then compound 3.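

In this assay, exchanging pyridin-2-yl for pyridin-3-yl keeps every atom and every counted donor and acceptor, yet it gives a 19-fold higher number from compound 2 to compound 3 (1.28 log units; beyond the scatter), so this place on the saturated chain carbon bound to an aromatic nitrogen responds strongly to how the pyridine ring is joined to the rest of the molecule. The earlier pair gave no hint of this, since 3-fluorophenyl and pyridin-2-yl could not be told apart there, whereas the exchange of 3-fluorophenyl for pyridin-3-yl gives a 21-fold higher number from compound 1 to compound 3 (1.31 log units; beyond the scatter), which makes compound 3 the weakest of the three and shows that this place does not accept every six-membered aromatic ring equally. Nothing available here explains why one way of joining the same ring costs so much more than the other.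

On these data alone, it remains open whether pyridin-4-yl at this place would give a number close to that of compound 2 or close to that of compound 3. As far as these compounds go, it is also open whether a carboxylic acid in place of the ethyl ester would preserve the gap between the two pyridine isomers.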